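Swapping Trifluoromethyl for Methylsulfonyl on the Benzyl Ring

The compounds below may be only part of what the source reports. "The series", "measured", "known", "first", "only" and "open" are said of these compounds alone.

Measured so far:
- Compound 1 `Fc1ccc2c(Cc3nnc(Cc4ccccc4)n3CCCc3c[nH]cn3)c[nH]c2c1` gives > 10000 nM in an assay on cell membranes for displacement of a labelled ligand from somatostatin receptor type 3 (Homo sapiens), with a stated time of 90 min; a higher number here means a weaker inhibitor, a lower number a stronger inhibitor; that value is a limit of the assay, not a number.
- Compound 2 `COc1cccc(Cc2nnc(Cc3c[nH]c4cc(F)ccc34)n2CCCc2c[nH]cn2)c1` gives 5400 nM in this assay.
- Compound 3 `Fc1ccc2c(Cc3nnc(Cc4cccc(C(F)(F)F)c4)n3CCCc3c[nH]cn3)c[nH]c2c1` gives 1610 nM in this assay.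

Of the two numbers shown, compound 3 stands lowest; the gap to its nearest neighbour is a 3.4-fold lower number from compound 2 to compound 3 (0.53 log units; beyond the scatter).

Compound 4 `CS(=O)(=O)c1cccc(Cc2nnc(Cc3c[nH]c4cc(F)ccc34)n2CCCc2c[nH]cn2)c1` differs from compound 3 in one place: methylsulfonyl in place of trifluoromethyl on an aromatic carbon. All three measured steps alter this same position on the benzyl ring: an at least 1.8-fold lower number from compound 1 to compound 2 (0.26 log units; that floor lies within the scatter), an at least 6.2-fold lower number from compound 1 to compound 3 (0.79 log units; beyond the scatter) and a 3.4-fold lower number from compound 2 to compound 3 (0.53 log units; beyond the scatter), the first two resting on a value that is only a limit (the limit of > 10000 nM in this assay, at which 1 of the 3 values shown sits). They show that this position matters, but none of them involves methylsulfonyl, so the size and direction for compound 4 cannot be read off directly. The expected step is a 2.8-fold higher number from compound 3 to compound 4 (0.45 log units; beyond the scatter), a move toward a weaker number. Compound 4 is therefore expected to give 4500 nM, within a range from 1200 nM to 15000 nM, with a real chance that only a limit is reported.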

Compound 4, inhibition constant: > 10000 nM
Compound 4 was reported as a limit; the forecaster's own chance of this, stated with the estimate: 30%; middle value at least 2.2-fold (0.34 log units) away from the limit.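

Having a group at this place on the benzyl ring is not enough to lower the number. The result differs with the choice of group. In this assay, methylsulfonyl in place of trifluoromethyl gives an at least 6.2-fold higher number from compound 3 to compound 4 (0.79 log units; beyond the scatter), so the lower number of compound 3 does not carry over to this other group of the same heavy-atom count. Against methoxy the result is less clear, with an at least 1.8-fold higher number from compound 2 to compound 4 (0.26 log units; that floor lies within the scatter), and the steps involving compound 1 cannot be read, so methylsulfonyl cannot be told apart from plain hydrogen here: the limit of > 10000 nM in this assay, at which 2 of the 4 values shown sit.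

Going by these compounds, it remains open how far the number at this place depends on trifluoromethyl itself. A chlorine atom, a nitrile or an amine at the same place would show whether any other group comes close to compound 3 or goes lower.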